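Human biotin ligase: a trifluoromethyl variant of a triazole series

The source may report more compounds than this note shows. Statements on the series, on what has been measured and on what is new or still open speak of the compounds shown alone.

Compound 1 `O=C1N[C@H]2[C@H](CS[C@H]2CCCCCc2cn(Cc3ccccc3O)nn2)N1` — in an assay on isolated protein for inhibition of biotin--protein ligase (Homo sapiens), read by scintillation counting, with a stated time of 10 min (on this read-out lower numbers stand for stronger inhibition and higher numbers for weaker inhibition), compound 1 gives > 16000 nM, which is a limit of the assay.
Compound 2 `O=C1N[C@H]2[C@H](CS[C@H]2CCCCCc2cn(Cc3cccc(O)c3)nn2)N1` — in this assay compound 2 gives > 16000 nM, also a limit of the assay.
Compound 3 `Cc1cccc(Cn2cc(CCCCC[C@@H]3SC[C@@H]4NC(=O)N[C@@H]43)nn2)c1` — in this assay compound 3 gives > 16000 nM, again a limit of the assay.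

Every measured value in this series sits at the same place, namely (the limit of > 16000 nM in this assay, at which 3 of the 3 values shown sit). Compound 3 therefore cannot be placed on a number at all; its result is a limit, as are the results of the two other compounds. The steps between the measured compounds, a step that the two limits leave unreadable from compound 1 to compound 2, a step that the two limits leave unreadable from compound 1 to compound 3 and a step that the two limits leave unreadable from compound 2 to compound 3, are unreadable for the same reason.

Compound 4 `O=C1N[C@H]2[C@H](CS[C@H]2CCCCCc2cn(Cc3cccc(C(F)(F)F)c3)nn2)N1` differs from compound 3 by trifluoromethyl in place of methyl on an aromatic carbon. Going by the values given here, no measured step in this assay has a readable size, so none of them indicates a direction for this change; the only thing that bears on it is that every result so far lies at the limit. Compound 4 is therefore expected to stay at or beyond that limit as well, and the step from compound 3 to compound 4 is estimated as a step that the limit leaves unreadable from compound 3 to compound 4. For compound 4 in this assay the estimated value is 30000 nM, with a range from 10000 nM to 100000 nM.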

Compound 4, inhibition constant: > 16000 nM
Compound 4: no number, only a limit; the forecaster's own chance of this, stated with the estimate: 85%; the middle value lies beyond the limit too.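

In this assay compound 4 gives > 16000 nM, which is a limit of the assay. No step to compound 4 from compound 1, compound 2 or compound 3 can be read, as all four results sit at one place: the limit of > 16000 nM in this assay, at which 4 of the 4 values shown sit.

The compounds shown leave open how strongly any of them inhibits the enzyme, and whether the different aromatic substituents change that inhibition at all.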